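Dropping One Trifluoromethyl from a Urea-Linked Pyrazole Series

A few compounds are considered here, and "the series" means these few. Any claim that something is new, unique, unknown or untested is made for them only; others in the source may bear on it.

Measured compounds, with the read-out from a functional assay on OVCAR-5 cells (Homo sapiens) for inhibition, read by sulforhodamine B assay, with a stated time of 48 h, tested at 10 uM; on this read-out higher numbers stand for a weaker effect at the one concentration tested and lower numbers for a stronger effect:

Compound 1, `COc1cc(Cl)cc(-c2nn(-c3cccc(NC(=O)c4ccc(Cl)c(Cl)c4)c3)cc2-c2ccncc2)c1`, gives 79.2%.
Compound 2, `COc1cc(Cl)cc(-c2nn(-c3cccc(NC(=O)Nc4cc(C(F)(F)F)cc(C(F)(F)F)c4)c3)cc2-c2ccncc2)c1`, gives 21.7%.

Going by the values given here, on these two numbers compound 2 stands lowest, which on this read-out means the stronger effect; the only other compound, compound 1, sits a long way higher, a gap well beyond the usual scatter. The two differ in more than one place, so nothing more than their two values can be taken from that pair.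

Compound 3, `COc1cc(Cl)cc(-c2nn(-c3cccc(NC(=O)Nc4cccc(C(F)(F)F)c4)c3)cc2-c2ccncc2)c1`, has not yet been measured. It differs from compound 2 in a single spot: hydrogen in place of trifluoromethyl on an aromatic carbon. The aromatic ring that carried two trifluoromethyl groups now keeps only one.

Among the compounds with values here, there is no measured step of this kind to lean on. Taking away part of the substitution that accompanies the low number of compound 2, the expected direction is upward, toward a weaker effect, by a moderate amount. The expected step is a number 20.3 percentage points higher from compound 2 to compound 3 (beyond the scatter). Compound 3 is therefore estimated at 42%, with a range from 22% to 70%.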

Compound 3, a percentage reported as activity, at one concentration (the size of the read-out at that concentration, not a potency): 34.1%
For compound 3 the middle estimate is 7.9 percentage points above the measured one, within the range that was stated.
By their numbers in this assay, from the lowest: compound 2; then compound 3; then compound 1.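

In this assay, hydrogen in place of trifluoromethyl on this aromatic carbon gives a number 12.4 percentage points higher from compound 2 to compound 3 (beyond the scatter), a modest step that shows the second trifluoromethyl group counts for something here, though the compound with only one still has a clear effect. The other single change is much larger: (3-(trifluoromethyl)phenyl)amino in place of 3,4-dichlorophenyl on a carbonyl carbon gives a number 45.1 percentage points lower from compound 1 to compound 3 (beyond the scatter), so in this small set the change on the carbonyl carbon moves the number further than the loss of one trifluoromethyl does. No measurement shown here explains either step.

The compounds shown compare only trifluoromethyl and hydrogen on this carbon, so they do not say how a nitrile, an amine or a longer chain would behave there, or what would happen if the remaining trifluoromethyl also gave way to hydrogen. On these data alone, each number is also a read-out at a single concentration rather than a potency, so how these compounds would compare across a range of concentrations stays open.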